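Ortho chloro on the aryl of the imidazole amide

The source may report more compounds than this note shows. Statements on the series, on what has been measured and on what is new or still open speak of the compounds shown alone.

Compound 3 `COc1cc2c(Oc3ccc(NC(=O)c4cn(-c5ccc(Cl)cc5)cn4)cc3F)ccnc2cc1OCCCN1CCCCC1` gives the highest number of the three measured in a functional assay on MKN-45 cells (Homo sapiens) for cytotoxicity, read by MTT assay, with a stated time of 72 h (on this read-out higher numbers stand for weaker inhibition and lower numbers for stronger inhibition), at 5910 nM. Compound 1 `COc1cc2c(Oc3ccc(NC(=O)c4cn(-c5ccc(Cl)cc5Cl)cn4)cc3F)ccnc2cc1OCCCN1CCN(C)CC1` stands nearest, with 4840 nM, a gap within the scatter. For the measured compounds named here, compound 2 `COc1cc2c(Oc3ccc(NC(=O)c4cn(-c5ccccc5OC)cn4)cc3F)ccnc2cc1OCCCN1CCCCC1` is the furthest, with 260 nM; the only single-point step recorded, a 23-fold higher number from compound 2 to compound 3 (1.36 log units; beyond the scatter), is large, but it concerns a different exchange on the aromatic nitrogen and does not bear directly on the present move.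

Compound 4 `COc1cc2c(Oc3ccc(NC(=O)c4cn(-c5ccc(Cl)cc5Cl)cn4)cc3F)ccnc2cc1OCCCN1CCCCC1` differs from compound 3 by chloro in place of hydrogen on an aromatic carbon. Going by the values given here, no measured pair isolates this change. The closest indication is compound 1, which carries the same 2,4-dichlorophenyl group with another amine tail and sits within the scatter of compound 3 in this assay. Taken together, the numbers give no ground for expecting a shift beyond the scatter in either direction, and a 1.2-fold lower number from compound 3 to compound 4 (0.07 log units; within the scatter) is the expected step, essentially flat. Compound 4 is therefore estimated at 5000 nM in this assay, with a range from 1500 nM to 16000 nM, the width reflecting that the ortho chloro has not been tested on this tail.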

Compound 4, half-maximal inhibitory concentration: 6240 nM
Compound 4: the middle estimate sits 1.2-fold (0.10 log units) below what was measured; low and high end bracket the measured number.
By their numbers in this assay, from the lowest: compound 2; then compounds 1, 3 and 4 (each within the scatter of the next).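

Chloro in place of hydrogen on an aromatic carbon, ortho to a large group, now has a direct reading in this assay: a 1.1-fold higher number from compound 3 to compound 4 (0.02 log units; within the scatter) places 4-chlorophenyl and 2,4-dichlorophenyl level on the piperidin-1-yl tail. The tail exchange also has its first single-place reading, and a 1.3-fold higher number from compound 1 to compound 4 (0.11 log units; within the scatter) leaves piperidin-1-yl and 4-methylpiperazin-1-yl level when 2,4-dichlorophenyl is present. The large separation from the 2-methoxyphenyl compound persists, with a 24-fold higher number from compound 2 to compound 4 (1.38 log units; beyond the scatter) alongside a 23-fold higher number from compound 2 to compound 3 (1.36 log units; beyond the scatter), so among the aryl groups shown on the aromatic nitrogen, only 2-methoxyphenyl stands apart from the chlorinated ones.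

No measurement available here accounts for any of these steps. Still open, on these data alone, is whether 2-chlorophenyl or 2-ethoxyphenyl on the same aromatic nitrogen would read with 2-methoxyphenyl or with the chlorinated aryl groups, and whether the level reading between the two amine tails would also hold with 2-methoxyphenyl in place.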